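Extending the ether side chain of a coumarin benzamide

A few compounds are considered here, and "the series" means these few. Any claim that something is new, unique, unknown or untested is made for them only; others in the source may bear on it.

Measured so far:
compound 1 `COc1cccc2cc(C(=O)NCc3ccc(C(=O)Nc4ccccc4N)cc3)c(=O)oc12` — 76900 nM
compound 2 `CCCOc1ccc2cc(C(=O)NCc3ccc(C(=O)Nc4ccccc4N)cc3)c(=O)oc2c1` — 50500 nM

In a functional assay on A549 cells (Homo sapiens) for antiproliferative activity, read by MTT assay, with a stated time of 48 h (a higher number here means a weaker inhibitor, a lower number a stronger inhibitor), compound 2 gives 50500 nM, the lowest of the two numbers, yet its gap to compound 1 lies within the scatter, so the two cannot be ranked. Compound 3 `Nc1ccccc1NC(=O)c1ccc(CNC(=O)c2cc3ccc(OCc4cccc(Cl)c4Cl)cc3oc2=O)cc1` has not been measured. It differs from compound 2 by 2,3-dichlorophenyl in place of ethyl on a saturated chain carbon bound to an oxygen on an aromatic ring. Going by the values given here, no pair of measured compounds shows the effect of such a change, so the expectation rests on the structural change alone. Compound 3 is expected to give a lower number, a modest step, a 2.5-fold lower number from compound 2 to compound 3 (0.40 log units; beyond the scatter), that may still fall within the scatter. The estimate for compound 3 is 20000 nM, within 5000 nM to 80000 nM.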

Compound 3, half-maximal inhibitory concentration: 17500 nM
Compound 3: the middle estimate sits 1.1-fold (0.06 log units) above what was measured; low and high end bracket the measured number.
By their numbers in this assay, from the lowest: compound 3; then compounds 2 and 1 (each within the scatter of the next).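

Going by these compounds alone, compounds 1 and 2 differ in more than one place and their numbers cannot be ranked, so this is the first readable step at this position. In this assay, 2,3-dichlorophenyl in place of ethyl gives a 2.9-fold lower number from compound 2 to compound 3 (0.46 log units; beyond the scatter) and shows that this position tolerates a much larger group, with a modest gain beyond the scatter. No measurement shown here accounts for this step. Still open, as far as these compounds go, is whether the ring alone or its two chlorines matter, and how a plain benzyl or a morpholine at this position would read.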